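Sulfonamide variation on the benzoxazole series: methyl for methoxy

The source may report more compounds than this note shows. Statements on the series, on what has been measured and on what is new or still open speak of the compounds shown alone.

The series keeps one core and varies the group on the sulfonyl sulfur. Compound 1 `O=S(=O)(Nc1ccc(-c2nc3ccccc3o2)cc1)c1ccc(Cl)s1` carries 5-chlorothiophen-2-yl and gives 31000 nM in an assay on cells for inhibition of HSP60/HSP10 (Homo sapiens), with a stated time of 60 min; on this read-out lower numbers stand for stronger inhibition and higher numbers for weaker inhibition. Compound 2 `O=S(=O)(Nc1ccc(-c2nc3ccccc3o2)cc1)c1ccc(O)cc1` carries 4-hydroxyphenyl and gives 78000 nM; compound 3 `COc1cccc(S(=O)(=O)Nc2ccc(-c3nc4ccccc4o3)cc2)c1` carries 3-methoxyphenyl and gives 80000 nM. Compound 3 has the highest number of the three, but compound 2 lies within the scatter of it, as the step of a 1.0-fold higher number from compound 2 to compound 3 (0.01 log units; within the scatter) shows; only compound 1 is clearly apart, by a 2.6-fold higher number from compound 1 to compound 3 (0.41 log units; beyond the scatter), and likewise a 2.5-fold higher number from compound 1 to compound 2 (0.40 log units; beyond the scatter).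

Compound 4 `Cc1cccc(S(=O)(=O)Nc2ccc(-c3nc4ccccc4o3)cc2)c1` is not yet measured. Its change from compound 3 is methyl in place of methoxy on an aromatic carbon. For the measured compounds named here, no measured step exchanges methoxy for methyl directly. The nearest comparison is the exchange of 4-hydroxyphenyl for 3-methoxyphenyl, which moved the number by a 1.0-fold higher number from compound 2 to compound 3 (0.01 log units; within the scatter) and so stayed within the scatter, while the larger shifts in the set both involve the thiophene of compound 1. A small exchange on the phenyl is therefore expected to leave this assay essentially unchanged, with no step beyond the scatter in either direction.

The number expected for compound 4 is 70000 nM, with a range from 35000 nM to 140000 nM. This estimate means a step of a 1.1-fold lower number from compound 3 to compound 4 (0.06 log units; within the scatter), expected to stay within the scatter.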

Compound 4, half-maximal inhibitory concentration: > 100000 nM
Compound 4: a limit, no number; the forecaster's own chance of this, stated with the estimate: 10%; middle value at least 1.4-fold (0.15 log units) away from the limit.
By their numbers in this assay, from the lowest: compound 1; then compounds 2 and 3 (each within the scatter of the next). At a limit, above all of these: compound 4.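

Compound 4 gives > 100000 nM in this assay, and this is a limit of the assay, not a number: the limit of > 100000 nM in this assay, at which 1 of the 4 values shown sits.

On these data alone, the exchange of methoxy for methyl gives an at least 1.2-fold higher number from compound 3 to compound 4 (0.09 log units; that floor lies within the scatter), and the exchange from 4-hydroxyphenyl to 3-methylphenyl gives an at least 1.2-fold higher number from compound 2 to compound 4 (0.10 log units; that floor lies within the scatter), so neither floor sets compound 4 apart from the earlier phenyl compounds, and the true size of both steps stays unknown. The step from the thiophene is an at least 3.2-fold higher number from compound 1 to compound 4 (0.50 log units; beyond the scatter), which shows that a methyl group on this aromatic carbon does not recover the number of compound 1, and that a phenyl with neither oxygen substituent fares no better here than the two phenyl compounds that carry one.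

The compounds shown leave open how an amine or a carboxylic acid on this aromatic carbon would read in this assay, and whether any substituted phenyl can match the 5-chlorothiophen-2-yl group. They also leave open whether a thiophene without its chlorine would stay with compound 1 or fall in with the phenyl compounds.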